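The source may hold more compounds than are shown below. What is called first, only, known or untested is meant among the compounds shown, and "the series" means these compounds.

Working notes on the series. In a functional assay on HT-29 cells (Homo sapiens) for inhibition, read by MTT assay, with a stated time of 120 h (a higher number here means a weaker inhibitor, a lower number a stronger inhibitor), compound 1 `CC(NC(=O)C#Cc1ccc(NC(=O)Nc2cc(C(F)(F)F)ccc2Cl)cc1)c1ccccc1` gives 3170 nM and compound 2 `O=C(/C=C/c1ccc(NC(=O)Nc2ccc(Cl)c(C(F)(F)F)c2)cc1)NC1CCC1` gives 4430 nM. Among the measured compounds shown here, these two values lie within the scatter of each other, so compound 2 stands level with compound 1 on the only numbers available.

Compound 3 `CNC(=O)/C=C(\C)c1ccc(NC(=O)Nc2ccc(Cl)c(C(F)(F)F)c2)cc1` departs from compound 2 by one change on an aromatic carbon, para to a large group: 1-methyl-2-(methylcarbamoyl)ethenyl in place of 2-(cyclobutylcarbamoyl)ethenyl (1-methyl-2-(methylcarbamoyl)ethenyl in place of 2-(cyclobutylcarbamoyl)ethenyl on an aromatic carbon). For the measured compounds named here, no measured pair isolates this change, so the data do not fix its size. Compound 1 and compound 2 differ in more than one place and still lie within the scatter, which gives no ground for expecting a large move. No step beyond the scatter is expected in this assay. The estimated step is a 1.1-fold higher number from compound 2 to compound 3 (0.05 log units; within the scatter). For compound 3 the expected value is 5000 nM, with an estimated range of 1800 nM to 14000 nM.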

Compound 3, half-maximal inhibitory concentration: > 50000 nM
Compound 3: a limit, no number; the forecaster's own chance of this, stated with the estimate: 15%; middle value at least 10-fold (1.00 log units) away from the limit.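

The one-place change at this position, on an aromatic carbon para to a large group, is not neutral in this assay and gives an at least 11-fold higher number from compound 2 to compound 3 (1.05 log units; beyond the scatter) when 1-methyl-2-(methylcarbamoyl)ethenyl replaces 2-(cyclobutylcarbamoyl)ethenyl. Compound 3 gives > 50000 nM as a limit of the assay and not a number. Compound 1 and compound 2 showed only values within the scatter, whereas this step lies beyond it, and its size is bounded on one side only: the limit of > 50000 nM in this assay, at which 1 of the 3 values shown sits.

Still open, as far as these compounds go, is which part of the change carries the step, the methyl on the ethenyl or the exchange of cyclobutyl for methyl on the amide, as the two enter together. Also open, from the compounds shown here alone, is how a longer chain on the amide nitrogen, or a carboxylic acid in place of the amide, would read in this assay at this position.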